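From anilino to (4-aminocyclohexyl)amino at the limit

The compounds below may be only part of what the source reports. "The series", "measured", "known", "first", "only" and "open" are said of these compounds alone.

Compound 1 `CC(C)(C)OC(=O)Nc1nc(-c2cc(F)ncc2Cl)cs1`: > 10000 nM
Compound 2 `COCCNc1cc(-c2csc(NCC3CCOCC3)n2)c(Cl)cn1`: > 10000 nM
Compound 3 `Clc1cnc(Nc2ccccc2)cc1-c1csc(NCC2CCOCC2)n1`: > 10000 nM

In a functional assay on MV4-11 cells (Homo sapiens) for antiproliferative activity, read by CellTiter-Glo, with a stated time of 72 h (a lower number here means a stronger inhibitor of growth, a higher number a weaker inhibitor of growth), compound 3 gives only a limit, > 10000 nM. It shares that position with the other two compounds: the limit of > 10000 nM in this assay, at which 3 of the 3 values shown sit. Compound 4 `N[C@H]1CC[C@H](Nc2cc(-c3csc(NCC4CCOCC4)n3)c(Cl)cn2)CC1` carries 4-aminocyclohexyl in place of phenyl on a nitrogen on an aromatic ring. Among the measured compounds shown here, one measured step bears on this same place, a step that the two limits leave unreadable from compound 2 to compound 3, and it offers no size to carry over. The expectation therefore rests on the structural change alone and points towards stronger growth inhibition, with an estimated at least 33-fold lower number from compound 3 to compound 4 (1.52 log units; beyond the scatter). This is a tentative call. For compound 4 the estimate is 300 nM, with an expected range of 20 nM to 5000 nM.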

Compound 4, concentration for 50% growth inhibition: 140 nM
For compound 4 the middle estimate is 2.1-fold (0.33 log units) above the measured one; low and high end bracket the measured number.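

At this position on the shared core, the nitrogen substituent can bring activity within reach of this assay, which neither phenyl nor 2-methoxyethyl did. The 4-aminocyclohexyl group gives an at least 71-fold lower number from compound 3 to compound 4 (1.85 log units; beyond the scatter), and in place of 2-methoxyethyl it gives an at least 71-fold lower number from compound 2 to compound 4 (1.85 log units; beyond the scatter). Compound 4 is the only compound shown that is not at the limit: the limit of > 10000 nM in this assay, at which 3 of the 4 values shown sit.

The compounds shown leave open whether the gain follows the amino group or the non-aromatic ring. From the compounds shown here alone, a plain cyclohexyl or a 4-hydroxycyclohexyl on this nitrogen would separate the two, and the other stereoisomer of the 4-aminocyclohexyl group also remains open.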